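This account rests on a few compounds, and the source may have more. Where it says the series, first, only, none or still open, it means among the compounds named here.

Measured compounds:
- Compound 1 `COc1ccc(/C=C(\C(=O)c2ccc(Br)cc2)S(=O)(=O)c2ccc(Br)cc2)cc1`: 25000 nM
- Compound 2 `Cc1ccc(S/C(=C/c2sccc2C)C(=O)c2ccc(Br)cc2)cc1`: 50000 nM
- Compound 3 `COc1ccc(/C=C(\C(=O)c2ccc(Br)cc2)S(=O)(=O)Cc2ccc(Cl)cc2)cc1`: 25000 nM

In a functional assay on DU-145 cells (Homo sapiens) for inhibition, read by trypan blue exclusion, with a stated time of 96 h (on this read-out higher numbers stand for weaker inhibition of growth and lower numbers for stronger inhibition of growth), compound 1 gives 25000 nM. It stands level with compound 3, and compound 2 lies within the usual scatter of both.

Compound 4 `O=C(/C(=C\c1ccc(Cl)c([N+](=O)[O-])c1)S(=O)(=O)c1ccc(Br)cc1)c1ccc(Br)cc1` keeps the rest of compound 1 but carries 4-chloro-3-nitrophenyl in place of 4-methoxyphenyl on a double-bonded chain carbon bound to a double-bonded chain carbon.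

Within the data shown here, only one measured step is available: no change at the digits printed from compound 1 to compound 3 (within the scatter). That change sits on a sulfonyl sulfur, so it bears on this swap only indirectly, showing that one other part of compound 1 could change without moving the number. Among the measured compounds shown here, no measured compound here makes this swap alone, so the evidence is thin. No step beyond the scatter is therefore expected in this assay, though with real uncertainty in either direction. The expected step is a 1.3-fold lower number from compound 1 to compound 4 (0.10 log units; within the scatter). For compound 4 the estimated value is 20000 nM, with an expected range from 5000 nM to 60000 nM.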

Compound 4, concentration for 50% growth inhibition: 10000 nM
Beside the measured number, compound 4's estimate is 2.0-fold (0.30 log units) above it; measured number inside the range.
By their numbers in this assay, from the lowest: compound 4; then compounds 1, 3 and 2 (each within the scatter of the next).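

In this assay, replacing 4-methoxyphenyl with 4-chloro-3-nitrophenyl on a double-bonded chain carbon bound to a double-bonded chain carbon gives a 2.5-fold lower number from compound 1 to compound 4 (0.40 log units; beyond the scatter). Among these compounds, this is the first step to pass beyond the scatter, though only modestly, and it shows that this position can shift the number, whereas the sulfonyl sulfur change gave no change at the digits printed from compound 1 to compound 3 (within the scatter). No measurement shown here gives any reason for the shift.

From the compounds shown here alone, the swap brings in a chlorine and a nitro group together, so their separate contributions remain unknown, as does the result of a ring carrying only one of them. Also open, going by these compounds, are whether an amine or a carboxylic acid on this ring would move the number further, and whether the same swap would have a similar effect with the 4-chlorobenzyl group of compound 3 on the sulfonyl sulfur.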